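The source may hold more compounds than are shown below. What is called first, only, known or untested is meant among the compounds shown, and "the series" means these compounds.

Compound 1 `C=Cn1c2ccc([N+](=O)[O-])cc2c(=O)n1Cc1ccccc1` is the reference of this set. In an ADME assay on L929 cells (Mus musculus) for cytotoxicity, read by resazurin assay, with a stated time of 48 h (a lower number here means that less compound is tolerated, a higher number that more compound is tolerated), compound 1 gives 160000 nM, the only number shown. Compound 2 `N#CCn1c2ccc([N+](=O)[O-])cc2c(=O)n1Cc1ccccc1` reaches only the limit > 256000 nM in this assay. Compound 3 `O=c1c2cc([N+](=O)[O-])ccc2n(CCCO)n1Cc1ccccc1` likewise stops at the limit > 256000 nM. Both replacements of the vinyl group therefore read as an at least 1.6-fold higher number from compound 1 to compound 2 (0.20 log units; that floor lies within the scatter) and an at least 1.6-fold higher number from compound 1 to compound 3 (0.20 log units; that floor lies within the scatter), each resting on (the limit of > 256000 nM in this assay, at which 2 of the 3 values shown sit).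

Compound 4 `CCOCCCn1c2ccc([N+](=O)[O-])cc2c(=O)n1Cc1ccccc1` is not yet measured; it differs from compound 1 by 3-ethoxypropyl in place of vinyl on an aromatic nitrogen. The two measured exchanges on the same aromatic nitrogen bear on it, and both run toward the limit. A step of a 1.6-fold higher number from compound 1 to compound 4 (0.20 log units; within the scatter) is therefore expected, probably again ending at the limit. Compound 4 is estimated at 256000 nM, with a range from 130000 nM to 500000 nM.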

Compound 4, concentration lethal to 50% of the cells: 170000 nM
Compound 4: middle estimate off by 1.5-fold (0.18 log units), on the high side; measured number inside the range.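

Going by these compounds alone, on this aromatic nitrogen, 3-ethoxypropyl is the first replacement of vinyl in this assay that ends in a number rather than a limit, with a 1.1-fold higher number from compound 1 to compound 4 (0.03 log units; within the scatter). Ethyl in place of hydrogen on the chain oxygen reads as an at least 1.5-fold lower number from compound 3 to compound 4 (0.17 log units; that floor lies within the scatter), and 2-ethoxyethyl in place of cyano reads as an at least 1.5-fold lower number from compound 2 to compound 4 (0.17 log units; that floor lies within the scatter). Both of these steps are floors only, because compound 2 and compound 3 stop at a limit: the limit of > 256000 nM in this assay, at which 2 of the 4 values shown sit.

On these data alone, the true size of those two steps stays open. Also open, as far as these compounds go, is whether an amine or a carboxylic acid at the end of this chain gives a number or a limit.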